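This account rests on a few compounds, and the source may have more. Where it says the series, first, only, none or still open, it means among the compounds named here.

Measured compounds in a functional assay on A549 cells (Homo sapiens) for inhibition, read by sulforhodamine B assay, with a stated time of 48 h; on this read-out lower numbers stand for stronger inhibition and higher numbers for weaker inhibition:
compound 1, `COc1ccc(C(OCc2ccccc2)c2cccc3ccccc23)c(OC)c1OC` — 13500 nM
compound 3, `COc1ccc(C(c2ccccc2O)c2cccc3ccccc23)c(OC)c1OC` — 13600 nM
compound 2, `COc1ccc(C(c2ccc(OCCO)cc2)c2cccc3ccccc23)c(OC)c1OC` — a limit of the assay, > 20000 nM

Compound 1 holds the lowest of the two numbers in this assay; compound 3 sits within the scatter of it, a 1.0-fold higher number from compound 1 to compound 3 (0.00 log units; within the scatter). Compound 2 reports only a limit (the limit of > 20000 nM in this assay, at which 1 of the 3 values shown sits). Compound 4, `COc1cc(COC(c2ccc(OC)c(OC)c2OC)c2cccc3ccccc23)cc(OC)c1`, is not yet measured. It differs from compound 1 by 3,5-dimethoxyphenyl in place of phenyl on a saturated chain carbon bound to an oxygen on a saturated carbon. The measured steps all exchange the benzyloxy group itself: an at least 1.4-fold higher number from compound 1 to compound 2 (0.17 log units; that floor lies within the scatter), a 1.0-fold higher number from compound 1 to compound 3 (0.00 log units; within the scatter), an at least 1.4-fold lower number from compound 2 to compound 3 (0.16 log units; that floor lies within the scatter). Among the measured compounds shown here, none of them moves beyond the scatter, and none varies the substitution on the benzyloxy phenyl, so they bear on the change to compound 4 only in showing how little this position has moved the number so far. For compound 4 the expectation is therefore no step beyond the scatter in this assay, a 1.0-fold lower number from compound 1 to compound 4 (0.02 log units; within the scatter). Compound 4 is estimated at 13000 nM, within 5000 nM to 35000 nM.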

Compound 4, half-maximal inhibitory concentration: 17500 nM
Estimate against measurement, compound 4: 1.3-fold (0.13 log units) below, and the stated range covers the measured number.
By their numbers in this assay, from the lowest: compounds 1, 3 and 4 (each within the scatter of the next). At a limit, above all of these: compound 2.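

Among the compounds shown here, compound 4 is the first entry that keeps the benzyl ether and alters only its ring, from benzyl to 3,5-dimethoxybenzyl. In this assay this gives a 1.3-fold higher number from compound 1 to compound 4 (0.11 log units; within the scatter), so the phenyl at this place accepts 3,5-dimethoxyphenyl, with its larger heavy-atom count and added hydrogen-bond acceptors, without a step beyond the scatter. No available evidence gives a cause for this step.

As far as these compounds go, whether an amine or a carboxylic acid on that phenyl, or a longer chain in place of benzyl, would move the number beyond the scatter remains open. From the compounds shown here alone, a single methoxy on the phenyl also remains open, so the contribution of each methoxy group in compound 4 cannot be separated.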